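The compounds below may be only part of what the source reports. "The series", "measured", "known", "first", "only" and "open" are said of these compounds alone.

Measured so far:
compound 1 `Cc1nn(-c2nc(-c3ccc(Cl)c(Cl)c3)c(SC(C)C)s2)c(C(=O)O)c1-c1cccc(F)c1` — 900 nM
compound 2 `Cc1oncc1-c1nc(-n2nc(C(=O)O)c(-c3cc(Cl)cc(Cl)c3)c2C)sc1SC(C)C` — > 44000 nM

Among the measured compounds shown here, in a functional assay on BJAB cells (Homo sapiens) for antiproliferative activity, with a stated time of 4 days (a lower number here means that less compound is needed, a higher number that more compound is needed for the effect), compound 1 gives 900 nM, the only plain number in the set. For compound 2 the entry of > 44000 nM is a limit of the assay, not a number; the set thus holds (the limit of > 44000 nM in this assay, at which 1 of the 2 values shown sits). For the measured compounds named here, no pair of measured compounds differs in a single place, so no measured step is available to size the change ahead.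

Compound 3 `Cc1nn(-c2nc(-c3ccc(Cl)c(Cl)c3)c(SC(C)C)s2)c(C(=O)O)c1-c1ccccc1Cl` is not yet measured. It differs from compound 1 as follows: 2-chlorophenyl in place of 3-fluorophenyl on an aromatic carbon. Lacking a comparable measured step, the expectation in this assay is a modest shift, at most slightly beyond the scatter, toward more compound being needed. Compound 3 is estimated at 1300 nM, within 400 nM to 4500 nM. This estimate means a step of a 1.4-fold higher number from compound 1 to compound 3 (0.16 log units; within the scatter), expected to sit near the edge of the scatter.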

Compound 3, half-maximal effective concentration: 13100 nM
Estimate against measurement, compound 3: 10-fold (1.00 log units) below; the whole stated range lies below it.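

In this assay, the aromatic carbon of the five-membered ring, next to the ring atom that bears a carboxy group, proves sensitive to the aryl group it carries: 2-chlorophenyl in place of 3-fluorophenyl gives a 15-fold higher number from compound 1 to compound 3 (1.16 log units; beyond the scatter). Among the compounds shown here, this is the only single-place step, and it lies beyond the scatter, so an exchange that leaves the heavy-atom count of the group unchanged is not a neutral one at this carbon. Nothing measured in the set bears on the reason for this step.

As far as these compounds go, what a 2-fluorophenyl or a 3-chlorophenyl group would give at this carbon stays open, so the exchange of halogen and the move of its place on the phenyl ring cannot yet be told apart. Equally open, from the compounds shown here alone, is how an aminophenyl group would behave at the same carbon.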